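Benzylsulfanyl in place of allylsulfanyl on a triazolyl phthalimide

The compounds below may be only part of what the source reports. "The series", "measured", "known", "first", "only" and "open" are said of these compounds alone.

Compound 1 `Cc1nnc(SCc2ccccc2)n1N1C(=O)c2ccccc2C1=O` gives > 200000 nM in a functional assay on A549 cells (Homo sapiens) for cytotoxicity, read by MTT assay, with a stated time of 48 h (on this read-out higher numbers stand for weaker inhibition and lower numbers for stronger inhibition), a limit.
Compound 2 `C#CCSc1nnc(CC)n1N1C(=O)c2ccccc2C1=O` gives > 200000 nM in this assay, a limit.
Compound 3 `C=CCSc1nnc(CC)n1N1C(=O)c2ccccc2C1=O` gives > 200000 nM in this assay, a limit.

Compound 3 stands at the limit of this assay, as do the other two measured compounds (the limit of > 200000 nM in this assay, at which 3 of the 3 values shown sit). The step that the two limits leave unreadable from compound 2 to compound 3 is therefore not readable in size. Compound 4 `CCc1nnc(SCc2ccccc2)n1N1C(=O)c2ccccc2C1=O` differs from compound 3 by phenyl in place of vinyl on a saturated chain carbon bound to a sulfur. Among the measured compounds shown here, no measured step bears on this change; compound 1, which also carries benzylsulfanyl, shows only a limit. In this assay compound 4 is expected to remain at the limit, a step of a number no higher from compound 3 to compound 4 (the limit leaves the size open) that is estimated as none beyond the scatter, with an estimated value of 200000 nM between 100000 nM and 600000 nM.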

Compound 4, half-maximal inhibitory concentration: > 200000 nM
Compound 4: a limit, no number; the forecaster's own chance of this, stated with the estimate: 90%; the middle value lies on the limit itself.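

Compound 4 also gives only a limit, so its steps from compound 1, compound 2 and compound 3 cannot be read. The compounds shown leave open how far any of these groups shifts the read-out in this assay, since every value stands at the same limit: the limit of > 200000 nM in this assay, at which 4 of the 4 values shown sit.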